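Ethoxy to hydroxy from compound 2 to compound 3

The source may hold more compounds than are shown below. What is called first, only, known or untested is meant among the compounds shown, and "the series" means these compounds.

compound 1 `COc1c(N2C[C@H]3CCCN(Cc4cn(CCCN5C(=O)/C(=N/O)c6ccccc65)nn4)[C@H]3C2)c(F)cc2c(=O)c(C(=O)O)cn(C3CC3)c12` gives 8 ug/mL
compound 2 `CCO/N=C1/C(=O)N(CCCn2cc(CN3CCC[C@@H]4CN(c5c(F)cc6c(=O)c(C(=O)O)cn(C7CC7)c6c5OC)C[C@@H]43)nn2)c2ccc(F)cc21` gives 4 ug/mL

In an ADME assay on Vero cells (Chlorocebus sabaeus) for cytotoxicity, read by MTT assay, with a stated time of 72 h (on this read-out higher numbers stand for lower toxicity in this test and lower numbers for higher toxicity in this test), compound 2 (4 ug/mL) and compound 1 (8 ug/mL) lie within the usual scatter of each other, so the two numbers show no real difference. Compound 3 `COc1c(N2C[C@H]3CCCN(Cc4cn(CCCN5C(=O)/C(=N/O)c6cc(F)ccc65)nn4)[C@H]3C2)c(F)cc2c(=O)c(C(=O)O)cn(C3CC3)c12` is still unmeasured. Relative to compound 2, compound 3 carries hydroxy where ethoxy stood (hydrogen in place of ethyl on an oxygen): hydrogen in place of ethyl on an oxygen, with double-bonded nitrogen as that oxygen's other neighbour. Within the data shown here, no step between measured compounds isolates this change, so the data do not give its size directly. No step beyond the scatter is expected in this assay, in either direction. This expectation rests only on the narrow spread of compound 1 (8 ug/mL) and compound 2 (4 ug/mL). The expected change is a 1.5-fold higher number from compound 2 to compound 3 (0.18 log units; within the scatter) and lies within the scatter. Compound 3 is estimated at 6 ug/mL with an expected range (2.5 ug/mL to 14 ug/mL).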

Compound 3, half-maximal cytotoxic concentration: 2 ug/mL
The estimate for compound 3 lay 3.0-fold (0.48 log units) above the measured number, and the stated range ends above it.
By their numbers in this assay, from the lowest: compounds 3, 2 and 1 (each within the scatter of the next, the first and the last beyond it).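

In this assay, hydrogen in place of ethyl on an oxygen whose other neighbour is double-bonded nitrogen gives a 2.0-fold lower number from compound 2 to compound 3 (0.30 log units; within the scatter), so with the fluoro group present, this change shows no real difference at this oxygen. Fluoro in place of hydrogen on an aromatic carbon gives a 4.0-fold lower number from compound 1 to compound 3 (0.60 log units; beyond the scatter) in this assay, the first one-place step in the series beyond the scatter, a modest move towards higher toxicity in this test. Nothing at hand accounts for either step.

From the compounds shown here alone, whether chloro or methoxy on that aromatic carbon would move the number as fluoro does remains open, as does the effect of a longer chain such as propoxy on the oxygen. Also open, going by these compounds, is whether the fluoro step would be the same size with ethoxy in place of hydroxy.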